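Swapping the Hydroxyphenyl Arm for a Thiophene Ring

The source may hold more compounds than are shown below. What is called first, only, known or untested is meant among the compounds shown, and "the series" means these compounds.

Measured compounds:
compound 1 `CC1=CC[C@H](C(C)(C)NC(=S)N/N=C/c2ccc(O)cc2)CC1` 82100 nM
compound 2 `CC1=CC[C@H](C(C)(C)NC(=S)N/N=C/c2ccccc2O)CC1` 3700 nM

Among the measured compounds shown here, compound 2 gives the lowest number of the two in a functional assay on NCI/ADR-RES cells (Homo sapiens) for inhibition, read by sulforhodamine B assay, with a stated time of 48 h; a lower number here means a stronger inhibitor of growth, a higher number a weaker inhibitor of growth; the only other value, from compound 1, is higher, a step of a 22-fold lower number from compound 1 to compound 2 (1.35 log units; beyond the scatter). The new compound 3 `CC1=CC[C@H](C(C)(C)NC(=S)N/N=C/c2cccs2)CC1` differs from compound 2 in one place: thiophen-2-yl in place of 2-hydroxyphenyl on a carbon with a double bond to nitrogen. For the measured compounds named here, no measured step changes this part of the molecule in the same way, since the one step available only moves a hydroxyl around a phenyl ring, so it bears on the new change only loosely. It does show that this arm of the molecule matters a great deal. A hydrogen-bond donor is lost entirely, and the expectation is therefore a weaker inhibitor of growth, with a step of a 4.1-fold higher number from compound 2 to compound 3 (0.61 log units; beyond the scatter). For compound 3 the estimate in this assay is 15000 nM, within 3000 nM to 80000 nM.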

Compound 3, concentration for 50% growth inhibition: 13600 nM
Compound 3: the middle estimate sits 1.1-fold (0.04 log units) above what was measured; low and high end bracket the measured number.
By their numbers in this assay, from the lowest: compound 2; then compound 3; then compound 1.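

Replacing 2-hydroxyphenyl with thiophen-2-yl gives a 3.7-fold higher number from compound 2 to compound 3 (0.57 log units; beyond the scatter) in this assay, so an arm with 0 hydrogen-bond donors still retains measurable growth inhibition. The same ring gives a 6.0-fold lower number from compound 1 to compound 3 (0.78 log units; beyond the scatter) as its other comparison, so the arm without a hydroxyl ranks ahead of 4-hydroxyphenyl but behind 2-hydroxyphenyl. At this position, then, a hydroxyl on the arm does not go with a lower number in every case, and its effect depends on which hydroxyphenyl group carries it. Nothing available explains this order. The compounds shown leave open how much of the advantage of compound 2 belongs to the hydroxyl itself, which plain phenyl or 2-methoxyphenyl on the same carbon could help to separate. Furan-2-yl, with oxygen in place of the ring sulfur, would likewise test whether that sulfur matters.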